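This account rests on a few compounds, and the source may have more. Where it says the series, first, only, none or still open, it means among the compounds named here.

Compound 2 `COc1cc(NC(C)CCCNC(=O)/C=C/c2ccc(OC)c(OC)c2)c2ncccc2c1` was tested in an ADME assay on L6 cells (Rattus norvegicus) for cytotoxicity, read by resazurin assay, with a stated time of 70 h; a lower number here means a stronger inhibitor, a higher number a weaker inhibitor. In this assay compound 2 gives only a limit, > 220000 nM, and no number. Compound 1 `COc1cc(NC(C)CCCNC(=O)/C(C)=C/c2ccccc2)c2ncccc2c1` likewise gives only a limit in this assay, > 250000 nM. So of the two values known here, one sits at the limit of > 220000 nM in this assay, at which 1 of the 2 values shown sits, and the other at the limit of > 250000 nM in this assay, at which 1 of the 2 values shown sits, and neither compound shows a measurable number. Compound 3 `COc1cc(NC(C)CCCNC(=O)/C=C/c2ccc(Cl)cc2)c2ncccc2c1` has not yet been measured in this assay. It differs from compound 2 by 4-chlorophenyl in place of 3,4-dimethoxyphenyl on a double-bonded chain carbon bound to a double-bonded chain carbon. For the measured compounds named here, no step between measured compounds is known, so nothing here tells how large this kind of change is. Because compound 2 sits at > 220000 nM, no step beyond the usual scatter is expected, and the step that the limit leaves unreadable from compound 2 to compound 3 is only an estimate. Compound 3 is expected to give about 250000 nM, within a range from 100000 nM to 500000 nM, most likely again reported only as a limit.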

Compound 3, half-maximal inhibitory concentration: 16800 nM
Beside the measured number, compound 3's estimate is 15-fold (1.17 log units) above it, and the stated range ends above it.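

In this assay, putting 4-chlorophenyl in place of 3,4-dimethoxyphenyl on a double-bonded chain carbon bound to a double-bonded chain carbon gives an at least 13-fold lower number from compound 2 to compound 3 (1.11 log units; beyond the scatter), so this position can clearly move the result. The 2-(4-chlorophenyl)ethenyl group on the carbonyl carbon, in place of 1-methyl-2-phenylethenyl, likewise gives an at least 14-fold lower number from compound 1 to compound 3 (1.17 log units; beyond the scatter), which shows that compound 3 is the only one of the three with a measured number. On these data alone, the true size of the step to compound 3 remains unknown, since compound 2 gives only a limit: the limit of > 220000 nM in this assay, at which 1 of the 3 values shown sits.

The compounds shown cannot tell whether gaining the chlorine or losing the two methoxy groups matters more, and they give no reason for the step. A 4-methoxyphenyl or 4-bromophenyl group at the same place would help separate these two parts of the change.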